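The compounds below may be only part of what the source reports. "The series", "measured", "known", "first", "only" and "open" are said of these compounds alone.

Measured compounds:
compound 1, `Nc1cc(-c2ccc(Br)cc2)nc2cc(-c3ccc(Cl)cc3)nn12`, 59.6%
compound 2, `Cc1ccc(-c2cc3nc(-c4ccc(Br)cc4)cc(N)n3n2)cc1`, 71.2%
compound 3, `Nc1cc(-c2ccc(Cl)cc2)nc2cc(-c3ccc(Br)cc3)nn12`, 13.5%

All three were tested in a functional assay on the whole organism (strain Wistar) for inhibition, with Rattus norvegicus as the target, read by paw edema, with stated times of 30 min and 1 h, at a dose of 50 mg/kg by the oral route; on this read-out lower numbers stand for less inhibition and higher numbers for more inhibition at the one dose given (going by the name of the read-out). Compound 1 and compound 2 share a core and differ in one place: methyl in place of chloro on an aromatic carbon. That change gave a number 11.6 percentage points higher from compound 1 to compound 2 (beyond the scatter). Compound 3 has the same atoms as compound 1 joined differently, and the difference between the two cores is not broken down here; compound 3 gives the lowest number of the three, and its gaps to compound 1 and to compound 2 both lie beyond the scatter, so on the core of compound 3 the same pair of aryl groups reads far weaker in this assay.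

Compound 4, `Cc1ccc(-c2cc(N)n3nc(-c4ccc(Br)cc4)cc3n2)cc1`, is not yet measured. Within the data shown here, it differs from compound 3 by methyl in place of chloro on an aromatic carbon, which is the same change, at the same kind of place, as the one between compound 1 and compound 2. Among the measured compounds shown here, the only measured instance of this change is the step from compound 1 to compound 2, which was modest and in the upward direction. Whether the core of compound 3 carries the change over in the same way is not known from the data, so the expectation rests on that single step alone. From compound 3 to compound 4 an estimated step of a number 11.5 percentage points higher from compound 3 to compound 4 (beyond the scatter) is therefore expected, beside the earlier one. Compound 4 is estimated to give 25% in this assay, expected to fall between 10% and 45%.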

Compound 4, a percentage reported as inhibition, in the whole organism at one dose (the size of the read-out at that dose, not a potency): 67.3%
Beside the measured number, compound 4's estimate is 42.3 percentage points below it; the whole stated range lies below it.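

In this assay the change from 4-chlorophenyl to 4-methylphenyl gave a number 53.8 percentage points higher from compound 3 to compound 4 (beyond the scatter), and set beside the earlier step, its size does not carry from one core to the other: the same change on two cores in this assay, a number 11.6 percentage points higher (beyond the scatter) from compound 1 to compound 2 and a number 53.8 percentage points higher (beyond the scatter) from compound 3 to compound 4, 42.2 percentage points apart, beyond the scatter of two such steps

Both steps point upward, so the direction held on the two cores shown, but two cores give no rule for a third, and the size of the change cannot be taken from one core to predict the other. The large step starts from the low number of compound 3 at 13.5%, and these values show neither why the two cores respond so differently nor whether the gap would persist at another dose, as each compound is read at a single dose only.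

Open, on these data alone, is whether other groups in place of chloro, such as fluoro, methoxy, a dimethylamino group or a carboxylic acid, follow methyl on either core, and whether their steps also differ in size between the two cores. As far as these compounds go, the bromophenyl group and the amine are common to all four compounds, so what replacing either with, for example, a plain phenyl group or an acetamide would do on each core remains open.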